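The compounds below may be only part of what the source reports. "The series", "measured", "known", "first", "only" and "open" are said of these compounds alone.

Measured compounds:
Compound 1: `COc1ncnc2c1c(-c1cccs1)cn2[C@@H]1O[C@H](CO)[C@@H](O)[C@H]1O` — 90 nM
Compound 2: `COc1ncnc2c1c(-c1ccsc1)cn2[C@@H]1O[C@H](CO)[C@@H](O)[C@H]1O` — 2570 nM

Of the compounds shown here, two have so far been tested in a functional assay on CCRF-CEM cells (Homo sapiens), read by MTT assay, with a stated time of 72 h; on this read-out lower numbers stand for stronger inhibition and higher numbers for weaker inhibition. Compound 1 gives 90 nM in this assay, while compound 2 gives 2570 nM. Within the data shown here, compound 2 stands at the highest of the two numbers; its nearest neighbour is compound 1, and the single measured step, a 29-fold higher number from compound 1 to compound 2 (1.46 log units; beyond the scatter), separates them. That step concerns the point of attachment of the thiophene ring and nothing else.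

Compound 3 `CSc1ncnc2c1c(-c1ccsc1)cn2[C@@H]1O[C@H](CO)[C@@H](O)[C@H]1O` differs from compound 2 by methylsulfanyl in place of methoxy on an aromatic carbon. Among the measured compounds shown here, no measured step bears on this change: the only step recorded touches the thiophene, and the exchange of methoxy for methylsulfanyl has no precedent among the measured compounds. The data therefore give no ground for a step beyond the scatter in either direction. Compound 3 is expected to come out at 2500 nM, with a range from 800 nM to 8000 nM. The step expected, a 1.0-fold lower number from compound 2 to compound 3 (0.01 log units; within the scatter), is estimated to stay within the usual scatter of this assay.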

Compound 3, half-maximal inhibitory concentration: > 20000 nM
Compound 3: no number, only a limit; the forecaster's own chance of this, stated with the estimate: 5%; middle value at least 8.0-fold (0.90 log units) from the limit.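

In this assay compound 3 gives > 20000 nM, which is a limit of the assay and not a number. The earlier compounds shown here showed only that the read-out responds to the point of attachment of the thiophene, whereas methylsulfanyl in place of methoxy on the aromatic carbon next to the ring nitrogen now gives an at least 7.7-fold higher number from compound 2 to compound 3 (0.89 log units; beyond the scatter), so the group at this second place on the shared core also matters, even though the two groups match in the counts of heavy atoms, donors and acceptors. The size of this step is itself bounded rather than measured, and how far the change reaches past that bound stays unknown: the limit of > 20000 nM in this assay, at which 1 of the 3 values shown sits.

The compounds shown leave open whether the same exchange would weaken the thiophen-2-yl compound 1 as strongly, since the change has been read on the thiophen-3-yl series alone. They also leave open how an amine, a methyl group or a longer chain such as ethoxy at this place would compare with methoxy, and so whether methoxy is specially favoured here or methylsulfanyl specially disfavoured.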